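A few compounds are considered here, and "the series" means these few. Any claim that something is new, unique, unknown or untested is made for them only; others in the source may bear on it.

Compounds measured so far in an assay on HEK293 cells for positive allosteric modulation of metabotropic glutamate receptor 3 (Rattus norvegicus), read by thallium flux, with a stated time of 2.5 min; a lower number here means a smaller maximal response, a higher number a larger maximal response:

Compound 1, `Cc1c(OCCCCOCOc2ccc(C(=O)O)cc2)ccc(C(=O)CC2CCCC2)c1O`, gives 46.9%.
Compound 2, `Cc1c(OCCCCOc2ccc(C(=O)O)cc2F)ccc(C(=O)CC2CCCC2)c1O`, gives 31.2%.
Compound 3, `Cc1cc(C(=O)O)ccc1OCCCCOc1ccc(C(=O)C(C)C)c(O)c1C`, gives 25.2%.

The number for compound 3 is the lowest of the three, but its gap to compound 2 is within the scatter of this assay, while compound 1 stands clearly higher. Among the measured compounds shown here, the only step between measured compounds, a number 15.7 percentage points lower from compound 1 to compound 2 (beyond the scatter), concerns the acid-bearing end of the molecule and not the ketone end.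

Compound 4, `Cc1cc(C(=O)O)ccc1OCCCCOc1ccc(C(=O)CC2CCCC2)c(O)c1C`, differs from compound 3 at the carbonyl: cyclopentylmethyl in place of isopropyl on a carbonyl carbon. For the measured compounds named here, no measured pair isolates this change. Compounds 1 and 2 do carry the cyclopentylmethyl group and both give numbers above compound 3, yet each also differs from compound 3 at the acid-bearing end, so they only hint at a direction.

Compound 4 is therefore expected to give 33%, in the range 20% to 48%, a step of a number 7.8 percentage points higher from compound 3 to compound 4 (within the scatter) that is estimated to be small and likely within the scatter.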

Compound 4, largest response reached (reported as percent of maximum), in percent of the reference or control that the assay uses: 28.4%
Compound 4: middle estimate off by 4.6 percentage points, on the high side; measured number inside the range.
By their numbers in this assay, from the lowest: compounds 3, 4 and 2 (each within the scatter of the next); then compound 1.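

In this assay, among the compounds shown here, this is the first direct test of the group on the carbonyl carbon, and cyclopentylmethyl in place of isopropyl gives a number 3.2 percentage points higher from compound 3 to compound 4 (within the scatter) in the maximal response, so the hint from compounds 1 and 2 does not hold up as a real gain. Methyl in place of fluoro on an aromatic carbon gives a number 2.8 percentage points lower from compound 2 to compound 4 (within the scatter) as well, while 4-carboxy-2-methylphenyl in place of (4-carboxyphenoxy)methyl on an oxygen gives a number 18.5 percentage points lower from compound 1 to compound 4 (beyond the scatter) and is the only step of the three to clear the scatter. Nothing available explains these results.

For the compounds shown here, only two groups on the carbonyl carbon appear here, so it remains open whether a phenyl ring or a longer straight carbon chain there would change the response. From the compounds shown here alone, it is equally open whether an amine at that place would do so.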